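Swapping 1H-indol-6-yl for 4-acetylphenyl on a shared core

The source may hold more compounds than are shown below. What is called first, only, known or untested is meant among the compounds shown, and "the series" means these compounds.

Three related compounds have been tested in a functional assay on HeLa cells (Homo sapiens) for inhibition, read by CCK-8 assay, with a stated time of 48 h; on this read-out lower numbers stand for stronger inhibition and higher numbers for weaker inhibition. Compound 1 `COc1cc(-c2ccnc3cc(-c4cn(CO)c5ccccc45)nn23)cc(OC)c1OC` gives 103 nM, and compound 3 `COc1cc(-c2ccnc3cc(-c4ccc5cc[nH]c5c4)nn23)cc(OC)c1OC` gives 125 nM. For the measured compounds named here, these two numbers lie within the usual scatter of each other, so they count as the same result, and compound 3 stands level with compound 1 as one of only two true numbers so far. Compound 2 `COc1cc(-c2cc3nccc(-c4c[nH]c5ccccc45)n3n2)cc(OC)c1OC` gives > 10000 nM, which is a limit and not a number.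

The next compound, compound 4 `COc1cc(-c2ccnc3cc(-c4ccc(C(C)=O)cc4)nn23)cc(OC)c1OC`, differs from compound 3 in one place: 4-acetylphenyl in place of 1H-indol-6-yl on an aromatic carbon. The 4-acetylphenyl group sits on an aromatic carbon of a five-membered aromatic ring with 2 nitrogen, where the 1H-indol-6-yl group stood. Going by the values given here, no measured pair shows a swap of this kind on its own, so any forecast here is loose and its range has to be wide.

Starting from compound 3 at 125 nM, a moderate move to a higher number, meaning weaker inhibition, is expected in this assay, with an estimated 5.6-fold higher number from compound 3 to compound 4 (0.75 log units; beyond the scatter). For compound 4 the expected value is 700 nM, with an estimated range from 120 nM to 5000 nM.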

Compound 4, half-maximal inhibitory concentration: 1810 nM
Compound 4: the middle estimate sits 2.6-fold (0.41 log units) below what was measured; low and high end bracket the measured number.
By their numbers in this assay, from the lowest: compounds 1 and 3 (each within the scatter of the next); then compound 4. At a limit, above all of these: compound 2.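

At this position, on an aromatic carbon of the five-membered aromatic ring with 2 nitrogen, the choice of group clearly matters: in this assay, 4-acetylphenyl in place of 1H-indol-6-yl gives a 14-fold higher number from compound 3 to compound 4 (1.16 log units; beyond the scatter), a large step well beyond the scatter. Both groups carry 9 heavy atoms, so the count of heavy atoms alone does not set the result, and a group of the same count can still give much weaker inhibition. Only compound 2 stands at a limit, which is not a number, and this step stays clear of it, so it can be read in full: the limit of > 10000 nM in this assay, at which 1 of the 4 values shown sits.

The swap changes several things at once, removing the five-membered ring and its hydrogen-bond donor while adding a carbonyl with its hydrogen-bond acceptor, so the compounds shown cannot say which of these changes accounts for the step. A plain phenyl group, or a phenyl ring carrying an amine or a carboxylic acid where the acetyl sits, would help to separate the effect of the lost ring from that of the added acetyl.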